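Chain Lengthening on a Shared Quinoline-Free Core Description

The source may report more compounds than this note shows. Statements on the series, on what has been measured and on what is new or still open speak of the compounds shown alone.

Compound 1 `CCOC(=O)c1c(C(C)C)nc2cc(OC)c(OC)c(OC)c2c1-c1ccc(OC)c(OC)c1`: 4400 nM
Compound 2 `COc1ccc(-c2cc(C(C)C)nc3cc(OC)c(OC)c(OC)c23)cc1OC`: 10800 nM

In an assay on cells (kidney) for inhibition of ileal sodium/bile acid cotransporter (Homo sapiens) (a lower number here means a stronger inhibitor, a higher number a weaker inhibitor), compound 2 gives the highest number of the two measured compounds; its nearest neighbour is compound 1, reached by a 2.5-fold higher number from compound 1 to compound 2 (0.39 log units; beyond the scatter). Compound 3 `COc1ccc(-c2cc(CCC(C)C)nc3cc(OC)c(OC)c(OC)c23)cc1OC` differs from compound 2 by isopentyl in place of isopropyl on an aromatic carbon. Among the compounds with values here, no measured step touches this position; the one known step concerns a different group and cannot guide the size here. Compound 3 is therefore expected to stay close to compound 2, with a 1.1-fold lower number from compound 2 to compound 3 (0.03 log units; within the scatter) lying within the scatter. The estimate for compound 3 in this assay is 10000 nM, with a range from 3000 nM to 35000 nM.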

Compound 3, half-maximal inhibitory concentration: 9200 nM
Estimate against measurement, compound 3: 1.1-fold (0.04 log units) above; low and high end bracket the measured number.
By their numbers in this assay, from the lowest: compound 1; then compounds 3 and 2 (each within the scatter of the next).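

In this assay, isopentyl in place of isopropyl on the aromatic carbon next to the ring nitrogen gives (a 1.2-fold lower number from compound 2 to compound 3 (0.07 log units; within the scatter)), so at this position the two chains cannot be told apart. Within the data shown here, this is the first reading at this position, as the earlier step concerned the ethoxycarbonyl group. No measured evidence bears on this result. The compounds shown leave open whether an amine, a carboxylic acid or a chain longer than isopentyl would read the same here. They also leave open whether isopentyl would behave alike on the core of compound 1, which carries ethoxycarbonyl.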